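The compounds below may be only part of what the source reports. "The series", "measured", "known", "first", "only" and "open" are said of these compounds alone.

Values in a functional assay on A549 cells (Homo sapiens) for antiproliferative activity, read by MTT assay, with a stated time of 72 h; a higher number here means a weaker inhibitor, a lower number a stronger inhibitor:
compound 1 `COc1cc(C(=O)c2sc3ccccc3c2-c2ccccc2)cc(OC)c1OC`: 5000 nM
compound 2 `COc1cc(C(=O)c2sc3ccccc3c2-c2ccc(F)cc2)cc(OC)c1OC`: 3200 nM
compound 3 `COc1ccc(-c2c(C(=O)c3cc(OC)c(OC)c(OC)c3)sc3ccccc23)c(OC)c1`: 5800 nM

Compound 3 sits within the scatter of the other two, with a 1.2-fold higher number from compound 1 to compound 3 (0.06 log units; within the scatter) and a 1.8-fold higher number from compound 2 to compound 3 (0.26 log units; within the scatter) as its steps. Compound 4 `COc1ccc(-c2c(C(=O)c3cc(OC)c(OC)c(OC)c3)sc3ccccc23)cc1C` differs from compound 3 on one aromatic carbon of the shared core: 4-methoxy-3-methylphenyl in place of 2,4-dimethoxyphenyl on an aromatic carbon is the whole change. Every aryl swap measured at this carbon, including a 1.6-fold lower number from compound 1 to compound 2 (0.19 log units; within the scatter), stayed within the scatter, although none of them tests this group. No step beyond the scatter is therefore expected in this assay, with a slight lean toward a lower number. The expected move is a 1.9-fold lower number from compound 3 to compound 4 (0.29 log units; within the scatter) at the middle of the estimate. For compound 4 the estimated value is 3000 nM, with an expected range from 500 nM to 8000 nM in this series.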

Compound 4, half-maximal inhibitory concentration: > 10000 nM
Compound 4 was reported as a limit; the forecaster's own chance of this, stated with the estimate: 5%; middle value at least 3.3-fold (0.52 log units) from the limit.
By their numbers in this assay, from the lowest: compounds 2, 1 and 3 (each within the scatter of the next). At a limit, above all of these: compound 4.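

In this assay, compound 4 is reported only as a limit: the limit of > 10000 nM in this assay, at which 1 of the 4 values shown sits.
This carbon does respond to the aryl group, with one step beyond the scatter: an at least 3.1-fold higher number from compound 2 to compound 4 (0.49 log units; beyond the scatter).
The other two steps, an at least 1.7-fold higher number from compound 3 to compound 4 (0.23 log units; that floor lies within the scatter) and an at least 2.0-fold higher number from compound 1 to compound 4 (0.30 log units; that floor lies within the scatter), have floors within the scatter, so the limit alone does not set compound 4 apart from compound 3 or compound 1.

The compounds shown do not separate the contribution of the methyl from that of the methoxy in 4-methoxy-3-methylphenyl. Going by these compounds, how an amine or a carboxylic acid on this aryl ring would read in this assay also remains open.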